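Swapping a Cyclohexyl for a tert-Butyl on the Core

A few compounds are considered here, and "the series" means these few. Any claim that something is new, unique, unknown or untested is made for them only; others in the source may bear on it.

Of the compounds shown here, two that share a common core have been measured so far. Compound 1 `c1cc(C2CCCCC2)ccc1NC1=NCCO1` carries a cyclohexyl group; in a functional assay on MCF7 cells (Homo sapiens) for inhibition, read by sulforhodamine B assay, with a stated time of 48 h (on this read-out lower numbers stand for stronger inhibition of growth and higher numbers for weaker inhibition of growth), compound 1 gives 17500 nM. Compound 2 `c1cc(OC2CCCCC2)ccc1NC1=NCCO1` gives 19100 nM in this assay. Among the measured compounds shown here, compound 1 has the lowest of the two numbers, yet its only neighbour, compound 2, sits within the usual scatter, so the two cannot be told apart on these data. The next compound, compound 3 `CC(C)(C)c1ccc(NC2=NCCO2)cc1`, differs from compound 1 in one place: tert-butyl in place of cyclohexyl on an aromatic carbon. For the measured compounds named here, no pair of measured compounds shows what such a change does in this assay, so the expectation rests on the two values alone. The step of a 1.1-fold higher number from compound 1 to compound 3 (0.06 log units; within the scatter) is expected to be small, most likely not beyond the scatter in either direction. Compound 3 is therefore estimated at 20000 nM, with a range from 8000 nM to 50000 nM.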

Compound 3, concentration for 50% growth inhibition: 3000 nM
Estimate against measurement, compound 3: 6.7-fold (0.82 log units) above; measured number outside the range, below it.
By their numbers in this assay, from the lowest: compound 3; then compounds 1 and 2 (each within the scatter of the next).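

The group on this aromatic carbon turns out to matter: in this assay, tert-butyl in place of cyclohexyl gives a 5.8-fold lower number from compound 1 to compound 3 (0.77 log units; beyond the scatter) and this step lies beyond the scatter. Growth inhibition at this position therefore depends on which carbon group sits there, and of these two groups, the one without a ring gives the stronger inhibition. The data offer no measurement that explains this difference.

A single pair cannot separate the loss of the ring from the drop in heavy atoms, so it remains unclear which of the two matters. Also open, from the compounds shown here alone, is how a smaller methyl group, a longer chain such as n-hexyl, or an amine or a carboxylic acid would behave on this same carbon.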